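The compounds below may be only part of what the source reports. "The series", "measured", "known", "first", "only" and "open" are said of these compounds alone.

Measured compounds:
Compound 1, `O=C(CCCCCCc1cccc(Cl)c1Cl)c1ncc(-c2ccccn2)o1` — 0.9 nM
Compound 2, `CSc1ccccc1CCCCCCC(=O)c1ncc(-c2ccccn2)o1` — 3.3 nM

Compound 2 stands at the higher of the two numbers measured in an assay for inhibition of Fatty-acid amide hydrolase 1 (Rattus norvegicus); a lower number here means a stronger inhibitor, a higher number a weaker inhibitor. For the measured compounds named here, its only neighbour is compound 1, and the step of a 3.7-fold higher number from compound 1 to compound 2 (0.56 log units; beyond the scatter) shows that exchanging one aryl group for another at the far end of the chain moves the number modestly. Compound 3, `CSc1cccc(CCCCCCC(=O)c2ncc(-c3ccccn3)o2)c1`, is the next candidate. Its difference from compound 2 is 3-(methylsulfanyl)phenyl in place of 2-(methylsulfanyl)phenyl on a saturated chain carbon, six bonds along the chain from a carbonyl carbon. Going by the values given here, no measured step bears directly on moving the methylsulfanyl group from one ring position to another; the one step available, a 3.7-fold higher number from compound 1 to compound 2 (0.56 log units; beyond the scatter), only indicates that aryl changes at this place have stayed within a modest range. Compound 3 is therefore expected to land close to compound 2, with the step of a 1.1-fold higher number from compound 2 to compound 3 (0.03 log units; within the scatter) estimated as small and of uncertain direction. The estimate for compound 3 is 3.5 nM, between 1 nM and 12 nM.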

Compound 3, inhibition constant: 4.2 nM
For compound 3 the middle estimate is 1.2-fold (0.08 log units) below the measured one; measured number inside the range.
By their numbers in this assay, from the lowest: compound 1; then compounds 2 and 3 (each within the scatter of the next).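

In this assay, the methylsulfanyl group on this saturated chain carbon gives no difference beyond the scatter between the 2-(methylsulfanyl)phenyl and 3-(methylsulfanyl)phenyl forms, with a 1.3-fold higher number from compound 2 to compound 3 (0.10 log units; within the scatter). The 2,3-dichlorophenyl group stays apart from this second form as well, with a 4.7-fold higher number from compound 1 to compound 3 (0.67 log units; beyond the scatter), so compound 1 is the strongest inhibitor of the three, and both methylsulfanyl compounds lie beyond the scatter from it. No evidence is available to explain these numbers.

The compounds shown leave open whether an amine or a carboxylic acid on the phenyl ring, in place of the methylsulfanyl group, would keep the number in this range. They also leave open how a longer chain between the carbonyl carbon and the aryl group would read in this assay.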